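The source may hold more compounds than are shown below. What is called first, only, known or untested is meant among the compounds shown, and "the series" means these compounds.

Compound 1 `O=C1C[C@H](OCc2cn(Cc3ccccc3)nn2)[C@H]2CO[C@@H]1O2`: in a functional assay on MDA-MB-231 cells (Homo sapiens) for cytotoxicity, read by MTT assay, with a stated time of 48 h (on this read-out higher numbers stand for weaker inhibition and lower numbers for stronger inhibition), compound 1 reaches only the assay limit, > 50000 nM.
Compound 2 `O=C1C[C@H](OCc2cn(-c3ccc([N+](=O)[O-])cc3)nn2)[C@H]2CO[C@@H]1O2`: in this assay compound 2 gives 24800 nM.
Compound 3 `O=C1C[C@H](OCc2cn(-c3ccccc3)nn2)[C@H]2CO[C@@H]1O2`: in this assay compound 3 gives 25200 nM.

Among the two numbers shown, compound 3 stands highest, with compound 2 nearest; the gap a 1.0-fold higher number from compound 2 to compound 3 (0.01 log units; within the scatter) lies within the scatter. Compound 1 sits at the limit of > 50000 nM in this assay, at which 1 of the 3 values shown sits.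

Compound 4 `O=C1C[C@H](OCc2cn(-c3ccccc3Br)nn2)[C@H]2CO[C@@H]1O2` differs from compound 3 by bromo in place of hydrogen on an aromatic carbon. Among the compounds with values here, two measured steps bear on this change: an at least 1.9-fold lower number from compound 1 to compound 3 (0.29 log units; that floor lies within the scatter) and a 1.0-fold higher number from compound 2 to compound 3 (0.01 log units; within the scatter), the latter showing that exchanging a substituent on the phenyl left the number within the scatter. Within the data shown here, no measured step introduces bromo. The step expected is therefore a 1.1-fold lower number from compound 3 to compound 4 (0.06 log units; within the scatter), within the scatter. Compound 4 is estimated at 22000 nM, between 9000 nM and 50000 nM.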

Compound 4, half-maximal inhibitory concentration: 22500 nM
Compound 4: middle estimate off by 1.0-fold (0.01 log units), on the low side, and the stated range covers the measured number.
By their numbers in this assay, from the lowest: compounds 4, 2 and 3 (each within the scatter of the next). At a limit, above all of these: compound 1.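

In this assay, bromo on an aromatic carbon, ortho to a large group, gives a 1.1-fold lower number from compound 3 to compound 4 (0.05 log units; within the scatter), so this place on the ring accepts a bromine without a readable shift. The change of benzyl to 2-bromophenyl gives an at least 2.2-fold lower number from compound 1 to compound 4 (0.34 log units; beyond the scatter), the only step from benzyl shown that clears the scatter, though it is only a floor. Compound 1 stands at a limit: the limit of > 50000 nM in this assay, at which 1 of the 4 values shown sits.

Going by these compounds, whether an amine or a carboxylic acid on this ring would move the number remains open. So does whether any group here can carry compound 3 beyond the scatter.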